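This account rests on a few compounds, and the source may have more. Where it says the series, first, only, none or still open, it means among the compounds named here.

Measured so far in an assay on isolated protein for inhibition of Amine oxidase [flavin-containing] A (Homo sapiens), read by fluorescence and Amplex Red, with a stated time of 30 min, tested at 0.01 nM; a higher number here means a stronger effect of the compound at the concentration tested, a lower number a weaker effect:
compound 1 `COCCNc1nnc(SCC(=O)N(Cc2cccc([N+](=O)[O-])c2)c2ccc(F)cc2)s1` — 13.5%
compound 2 `CCCNc1nnc(SCC(=O)N(Cc2cccc([N+](=O)[O-])c2)c2ccc(F)cc2)s1` — 8.5%

Compound 2 stands beside compound 1 alone; the step of a number 5 percentage points lower from compound 1 to compound 2 (within the scatter) does not separate the two. Compound 3 `CCNc1nnc(SCC(=O)N(Cc2cccc([N+](=O)[O-])c2)c2ccc(F)cc2)s1` differs from compound 2 by hydrogen in place of methyl on a saturated chain carbon, two bonds along the chain from a nitrogen on an aromatic ring, that is propyl to ethyl. Within the data shown here, the one measured step, a number 5 percentage points lower from compound 1 to compound 2 (within the scatter), also alters this chain at the same place and stayed within the scatter, so in this assay no step beyond the scatter is expected here either. Compound 3 is therefore estimated at 9% in this assay, with a range from 0% to 20%, the expected step being a number 0.5 percentage points higher from compound 2 to compound 3 (within the scatter).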

Compound 3, a percentage reported as inhibition, at one concentration (the size of the read-out at that concentration, not a potency): 10.3%
Compound 3: middle estimate off by 1.3 percentage points, on the low side, within the range that was stated.
By their numbers in this assay, from the lowest: compounds 2, 3 and 1 (each within the scatter of the next).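

In this assay the change from propylamino to ethylamino gives a number 1.8 percentage points higher from compound 2 to compound 3 (within the scatter) and hydrogen in place of methoxy on the same chain carbon gives a number 3.2 percentage points lower from compound 1 to compound 3 (within the scatter) at this position. Taking off either chain end therefore leaves the read-out within the scatter, so ethylamino, propylamino and the methoxy-bearing chain are not told apart at the concentration tested. Nothing available bears on the reason for this. Still open, going by these compounds, is whether an amine or a carboxylic acid at the chain end, or a longer chain, would give a step beyond the scatter.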